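Trimming the Ether Side Chain in a Growth-Inhibition Series

A few compounds are considered here, and "the series" means these few. Any claim that something is new, unique, unknown or untested is made for them only; others in the source may bear on it.

Compound 1 `CCCCCCOc1cccc(O)c1C(=O)/C=C/c1ccc(O)cc1` reaches only the assay limit of > 30000 nM in a functional assay on NCI-H23 cells (Homo sapiens) for antiproliferative activity, read by sulforhodamine B assay; on this read-out lower numbers stand for stronger inhibition of growth and higher numbers for weaker inhibition of growth.
Compound 2 `O=C(/C=C/c1ccc(O)cc1)c1c(O)cccc1OCC1CCCCC1` likewise reaches only the assay limit of > 30000 nM in this assay.
Compound 3 `CC(C)CCOc1cccc(O)c1C(=O)/C=C/c1ccc(O)cc1` gives 12100 nM in this assay.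

Among the compounds with values here, compound 3 thus holds the only measured number in the set; the other two values are limits (the limit of > 30000 nM in this assay, at which 2 of the 3 values shown sit). The unmeasured compound 4 `CC(C)COc1cccc(O)c1C(=O)/C=C/c1ccc(O)cc1` differs from compound 3 by isopropyl in place of isobutyl on a saturated chain carbon bound to an oxygen on an aromatic ring. Two measured steps point the same way: an at least 2.4-fold lower number from compound 1 to compound 3 (0.39 log units; beyond the scatter) and an at least 2.4-fold lower number from compound 2 to compound 3 (0.39 log units; beyond the scatter), each swapping a larger chain for a smaller one and each giving an at least modestly lower number. Isopropyl in place of isobutyl is a shorter step in chain length than either, so for compound 4 the expected step is a 1.5-fold lower number from compound 3 to compound 4 (0.18 log units; within the scatter). Compound 4 is therefore estimated at 8000 nM, within 3000 nM to 25000 nM.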

Compound 4, concentration for 50% growth inhibition: 3220 nM
The estimate for compound 4 lay 2.5-fold (0.40 log units) above the measured number, within the range that was stated.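

In this assay, isopropyl in place of isobutyl gives a 3.8-fold lower number from compound 3 to compound 4 (0.57 log units; beyond the scatter), so even a small trim of this ether chain, isopentyloxy to isobutoxy, changes the result measurably. Compared with the larger chains, the same change gives an at least 9.3-fold lower number from compound 2 to compound 4 (0.96 log units; beyond the scatter) and an at least 9.3-fold lower number from compound 1 to compound 4 (0.96 log units; beyond the scatter). Both sizes are only minimum values: the limit of > 30000 nM in this assay, at which 2 of the 4 values shown sit.

On these data alone, whether trimming keeps lowering the number with a still shorter chain, such as ethyl or methyl, remains open. So does the effect of an amine or a carboxylic acid at the end of this chain.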